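Swapping the pyridine on the alkyne of compound 2

The source may hold more compounds than are shown below. What is called first, only, known or untested is meant among the compounds shown, and "the series" means these compounds.

Two compounds share one core and differ only in the aromatic group attached to the triple bond. Compound 1 is `Cc1ccc(-n2nccn2)c(C(=O)N2C[C@H](C#Cc3cncc(CO)c3)CC[C@H]2C)c1` and compound 2 is `Cc1ccc(-n2nccn2)c(C(=O)N2C[C@H](C#Cc3cccnc3O)CC[C@H]2C)c1`. In an assay on cells for binding affinity to Orexin receptor type 2 (Homo sapiens), read by radioligand binding (on this read-out lower numbers stand for stronger inhibition and higher numbers for weaker inhibition), compound 1 gives 32 nM, and in this assay compound 2 gives 24 nM. Compound 2 therefore stands at the lowest of the two numbers, but the only gap shown, a 1.3-fold lower number from compound 1 to compound 2 (0.12 log units; within the scatter), lies within the scatter, so the two compounds cannot be told apart on these figures.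

Compound 3 is `Cc1ccc(-n2nccn2)c(C(=O)N2C[C@H](C#Cc3ccc(F)cn3)CC[C@H]2C)c1`. It differs from compound 2 in one place: 5-fluoropyridin-2-yl in place of 2-hydroxypyridin-3-yl on a triple-bonded carbon. For the measured compounds named here, the single measured step, a 1.3-fold lower number from compound 1 to compound 2 (0.12 log units; within the scatter), shows that exchanging one pyridinyl group on the triple bond for another left the number essentially unchanged. Going by the values given here, that step is the only guide, and the group entering in compound 3 is of a different kind from either group measured so far, so the guide is weak. The expected step from compound 2 to compound 3 is therefore a 1.7-fold higher number from compound 2 to compound 3 (0.22 log units; within the scatter), none beyond the scatter but with wide uncertainty. Compound 3 is estimated at 40 nM, within a range from 12 nM to 130 nM.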

Compound 3, inhibition constant: 1.1 nM
For compound 3 the middle estimate is 36-fold (1.56 log units) above the measured one; measured number below the stated range.
By their numbers in this assay, from the lowest: compound 3; then compounds 2 and 1 (each within the scatter of the next).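

The earlier pair suggested that this position on the triple-bonded carbon was tolerant, but the new result shows that it can respond strongly to the group placed there. In this assay, 5-fluoropyridin-2-yl gives a 22-fold lower number from compound 2 to compound 3 (1.34 log units; beyond the scatter) and a 29-fold lower number from compound 1 to compound 3 (1.46 log units; beyond the scatter), and both steps are large and beyond the scatter. The step from 2-hydroxypyridin-3-yl keeps the heavy-atom count and the single six-membered aromatic ring with one hetero atom, so neither of those counts separates the two groups, although the hydrogen-bond donor and acceptor counts do differ; no supporting measurement is available to explain the gain.

This single change removes the hydroxyl group, adds fluorine and alters how the pyridine ring is attached to the triple bond, so the compounds shown cannot assign the step to any one of these differences. Unsubstituted pyridin-2-yl and 5-fluoropyridin-3-yl would help pull these apart, while 5-chloropyridin-2-yl would test whether fluorine itself matters or another halogen can take its place.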